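Swapping Acetyl for Cyano at the Chain End

The compounds below may be only part of what the source reports. "The series", "measured", "known", "first", "only" and "open" are said of these compounds alone.

In an ADME assay on TZM cells (Homo sapiens) for cytotoxicity, read by XTT assay, with a stated time of 4 days (a higher number here means that more compound is tolerated, a lower number that less compound is tolerated), compound 3 `CC(=O)/C=C/c1cc(C)c(Oc2ccc([N+](=O)[O-])c(Nc3ccc(C#N)cc3)n2)c(C)c1` gives > 46700 nM, which is a limit of the assay and not a number. Compound 1 `Cc1cc(Br)cc(C)c1Oc1ccc([N+](=O)[O-])c(Nc2ccc(C#N)cc2)n1`, with bromo in place of the chain, also gives only a limit, > 45600 nM. Among the measured compounds shown here, compound 2 `Cc1cc(/C=C/C(=O)O)cc(C)c1Oc1ccc([N+](=O)[O-])c(Nc2ccc(C#N)cc2)n1`, which carries 2-carboxyethenyl, gives the only true number, 27800 nM.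

Compound 4 `Cc1cc(/C=C/C#N)cc(C)c1Oc1ccc([N+](=O)[O-])c(Nc2ccc(C#N)cc2)n1` differs from compound 3 at the end of the chain, 2-acetylethenyl becoming 2-cyanoethenyl: cyano in place of acetyl on a double-bonded chain carbon bound to a double-bonded chain carbon.

For the measured compounds named here, no measured step makes this exact change, but three touch the same place. The closest is an at least 1.6-fold higher number from compound 2 to compound 3 (0.22 log units; that floor lies within the scatter), which also alters the group at the chain end. Next comes an at least 1.6-fold lower number from compound 1 to compound 2 (0.21 log units; that floor lies within the scatter). The third, a step that the two limits leave unreadable from compound 1 to compound 3, adds nothing. So changes here have not yet shown a step beyond the scatter.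

Going by the values given here, the expected change is small and leans downward, since compound 2 gives 27800 nM, the only true number among the three measured compounds. The expected size is an at least 1.5-fold lower number from compound 3 to compound 4 (0.19 log units; that floor lies within the scatter). Compound 4 is estimated at 30000 nM, with an expected range from 11000 nM to 55000 nM.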

Compound 4, half-maximal cytotoxic concentration: > 48600 nM
Compound 4: only a limit was reported (the forecaster's own chance of this, stated with the estimate: 50%); middle value at least 1.6-fold (0.20 log units) from the limit.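

With 2-cyanoethenyl at this position, compound 4 also ends at a limit of the assay and not at a number: the limit of > 48600 nM in this assay, at which 1 of the 4 values shown sits.

In this assay, cyano in place of carboxy at the chain end gives an at least 1.7-fold higher number from compound 2 to compound 4 (0.24 log units; that floor lies within the scatter). The steps from compound 3 and from compound 1 to compound 4 cannot be read, as each joins two limits, so the change from acetyl to cyano has no measured size, and compound 2 remains the only one of the four with a true number.

Going by these compounds, what the true numbers of compounds 1, 3 and 4 are stays open, as does whether any change at this position can move the number beyond the scatter. On these data alone, how an amine or a longer chain at this place would read in this assay is also open.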